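Bromo to cyanosulfanyl on the fused core: working notes

The compounds below may be only part of what the source reports. "The series", "measured", "known", "first", "only" and "open" are said of these compounds alone.

Three compounds have been measured in a functional assay on HeLa cells (Homo sapiens) for cytotoxicity, with a stated time of 72 h; on this read-out lower numbers stand for stronger inhibition and higher numbers for weaker inhibition:

compound 1 `Clc1ccc(Cc2nn3c(Br)c(-c4ccc(Br)cc4)nc3s2)cc1`: 188000 nM
compound 2 `O=c1oc2ccccc2cc1-c1nc2sc(Cc3ccc(Cl)cc3)nn2c1Br`: 4500 nM
compound 3 `N#CSc1c(-c2ccc([N+](=O)[O-])cc2)nc2sc(Cc3ccc(Cl)cc3)nn12`: 16000 nM

Compound 2 stands at the lowest of the three numbers. Its nearest neighbour is compound 3, whose number is higher by a gap beyond the scatter; compound 1 is furthest, higher by a gap that is also beyond the scatter. Among the compounds with values here, compound 1 and compound 3 differ from each other in two places at once, so their two values show only that compound 1 sits far above compound 3 in this assay, not what either single change contributes.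

Compound 4 `N#CSc1c(-c2cc3ccccc3oc2=O)nc2sc(Cc3ccc(Cl)cc3)nn12` differs from compound 2 by cyanosulfanyl in place of bromo on an aromatic carbon. Within the data shown here, no pair of measured compounds differs in this place alone, so the size of this step cannot be read from the data. With nothing to set a direction, no step beyond the scatter is assumed, and the number of compound 4 is expected to stay close to that of compound 2 in this assay. Compound 4 is therefore estimated at 5000 nM, with a range from 1500 nM to 17000 nM. This estimate means an expected step of a 1.1-fold higher number from compound 2 to compound 4 (0.05 log units; within the scatter).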

Compound 4, half-maximal inhibitory concentration: 1000 nM
The estimate for compound 4 lay 5.0-fold (0.70 log units) above the measured number, and the stated range ends above it.
By their numbers in this assay, from the lowest: compound 4; then compound 2; then compound 3; then compound 1.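

Cyanosulfanyl in place of bromo gives a 4.5-fold lower number from compound 2 to compound 4 (0.65 log units; beyond the scatter) in this assay and so supplies the first step in this series that can be read at a single place, on the aromatic carbon next to the ring nitrogen. The number is therefore not indifferent to the group at this place: a group of 3 heavy atoms with 2 hydrogen-bond acceptors, entering for a single bromine, lowers the number, although the step is modest and rests on this one pair. Nothing measured here gives a reason for the step.

As far as these compounds go, whether the same change gives a step of like size when the large group differs, as it does in compound 1 and compound 3, stays open. Equally open, from the compounds shown here alone, is how this place responds to other groups, such as chloro, methylsulfanyl, an amine or a plain nitrile, which could show whether the sulfur, the triple bond or the size of the entering group goes with the lower number.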